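This account rests on a few compounds, and the source may have more. Where it says the series, first, only, none or still open, it means among the compounds named here.

Two esters of the shared core have been tested for cytotoxicity so far. Compound 1 `N#CCC(=O)OCCc1c(-c2ccccc2Cl)c2cc(Cl)ccc2[nH]c1=O` in an ADME assay on HepG2 2.2.15 cells (Homo sapiens) for cytotoxicity (on this read-out lower numbers stand for higher toxicity in this test and higher numbers for lower toxicity in this test), gives 100000 nM. Among the measured compounds shown here, compound 2 `O=C(OCCc1c(-c2ccccc2Cl)c2cc(Cl)ccc2[nH]c1=O)c1ccco1` in this assay gives 98000 nM; the step of a 1.0-fold lower number from compound 1 to compound 2 (0.01 log units; within the scatter) is the only measured step, and on these two numbers compound 2 stands at the lower of the two, within the scatter of compound 1. Compound 3 `C/C=C(\C)C(=O)OCCc1c(-c2ccccc2Cl)c2cc(Cl)ccc2[nH]c1=O`, still unmeasured, carries the change 1-methylprop-1-en-1-yl in place of furan-2-yl on a carbonyl carbon relative to compound 2. For the measured compounds named here, the one step known, a 1.0-fold lower number from compound 1 to compound 2 (0.01 log units; within the scatter), changed the group on the carbonyl carbon without moving the number, so a further exchange at the same place is expected to stay flat as well, with no step beyond the scatter in either direction. Compound 3 is therefore expected to give about 98000 nM in this assay, within a range of 50000 nM to 150000 nM, which means the expected step of no change at the digits printed from compound 2 to compound 3 (within the scatter).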

Compound 3, half-maximal cytotoxic concentration: 350000 nM
Compound 3: the middle estimate sits 3.6-fold (0.55 log units) below what was measured; the whole stated range lies below it.
By their numbers in this assay, from the lowest: compounds 2 and 1 (each within the scatter of the next); then compound 3.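

The group on the carbonyl carbon can move the number in this assay after all: 1-methylprop-1-en-1-yl gives a 3.6-fold higher number from compound 2 to compound 3 (0.55 log units; beyond the scatter) and a 3.5-fold higher number from compound 1 to compound 3 (0.54 log units; beyond the scatter) as the steps that leave the scatter, both towards lower toxicity in this test. A ring alone does not sort the three esters, since furan-2-yl carries one and cyanomethyl does not, yet those two stay within the scatter of each other while compound 3 stands apart from both. No available data give a reason for this shift.

On these data alone, whether the step belongs to the double bond or to the four-carbon group as a whole stays open, and a saturated butyl group on the same carbonyl carbon would separate the two. As far as these compounds go, whether an amine or a carboxylic acid at this place would move the number towards higher toxicity also stays open.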